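The source may report more compounds than this note shows. Statements on the series, on what has been measured and on what is new or still open speak of the compounds shown alone.

Two members of the series have been measured in an assay on isolated protein for inhibition of MAP kinase-activated protein kinase 5 (Homo sapiens), read by mobility shift assay, tested at 30 uM; a higher number here means more inhibition at the concentration tested (going by the name of the read-out), a lower number less inhibition. Compound 1 `COc1cccc(-c2cc3[nH]nc(N)c3c(=O)[nH]2)c1` gives 10%, and compound 2 `CC(C)(C)c1cc2nn(-c3ccccc3)c(N)c2c(=O)[nH]1` gives 2%, the lower of the two numbers, although the gap to compound 1 lies within the usual scatter of this read-out. Compound 1 and compound 2 differ in more than one place, so no single step can be read from that pair. Compound 3 `COc1ccc(-c2cc3nn(-c4ccccc4)c(N)c3c(=O)[nH]2)cc1` differs from compound 2 in one place: 4-methoxyphenyl in place of tert-butyl on an aromatic carbon. Among the measured compounds shown here, with no measured step of this kind to lean on, the step of a number 6 percentage points higher from compound 2 to compound 3 (within the scatter) is expected to be small, not beyond the scatter. Compound 3 is expected to give 8%, within 0% to 25%.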

Compound 3, a percentage reported as inhibition, at one concentration (the size of the read-out at that concentration, not a potency): 12%
Beside the measured number, compound 3's estimate is 4 percentage points below it; the range from low to high includes it.
By their numbers in this assay, from the lowest: compounds 2, 1 and 3 (each within the scatter of the next).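

In this assay the change from tert-butyl to 4-methoxyphenyl, on the aromatic carbon next to the ring nitrogen, gives a number 10 percentage points higher from compound 2 to compound 3 (within the scatter) and so shows no shift beyond the scatter. This position therefore carries either an aromatic ring or a branched alkyl group, with compound 3 at 12% and inhibition still weak at the tested concentration. No evidence bears on the cause of this step.

On these data alone, whether an amine or a carboxylic acid on this carbon would lift inhibition beyond the scatter remains open. As far as these compounds go, the effect of a morpholine ring here also remains open.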